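Series notes: methyl on the ring amine nitrogen

This account rests on a few compounds, and the source may have more. Where it says the series, first, only, none or still open, it means among the compounds named here.

Measured so far in a functional assay on HeLa cells for agonist activity at 5-hydroxytryptamine receptor 6 (Homo sapiens), read by cAMP accumulation and immunoassay; on this read-out lower numbers stand for smaller maximal responses and higher numbers for larger maximal responses:
compound 1 `CN1CCC(n2cc(S(=O)(=O)c3cccc(F)c3)c3cccnc32)C1`: 54%
compound 2 `CN1CCCC(n2cc(S(=O)(=O)c3cccc(C(F)(F)F)c3)c3cccnc32)C1`: 66%
compound 3 `O=S(=O)(c1cccc(F)c1)c1cn(C2CCCNC2)c2ncccc12`: 84%

Compound 3 gives the highest of the three numbers in this assay; its nearest neighbour is compound 2, and compound 1 lies furthest from it, both gaps beyond the scatter.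

Compound 4 `CN1CCCC(n2cc(S(=O)(=O)c3cccc(F)c3)c3cccnc32)C1` is not yet measured. Relative to compound 3 the change is methyl in place of hydrogen on an amine nitrogen in a ring. Within the data shown here, only one measured step differs in a single place, a number 30 percentage points higher from compound 1 to compound 3 (beyond the scatter), and that step also swaps the ring, so it does not isolate the methyl. Compound 2 carries the same 1-methylpiperidin-3-yl as compound 4 but a trifluoromethyl where compound 4 has fluorine. In this assay compound 2 gives 66%. Compound 1, also with a methyl on its ring amine nitrogen, gives 54%. Both methylated compounds sit below compound 3. The expectation is therefore a step downward in this assay, of moderate size, with the estimate for compound 4 falling between the values of compound 2 and compound 3: a number 16 percentage points lower from compound 3 to compound 4 (beyond the scatter). Compound 4 is expected to give 68%, within a range of 52% to 84%.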

Compound 4, largest response reached (Emax), in percent of the reference or control that the assay uses: 75%
Estimate against measurement, compound 4: 7 percentage points below; measured number inside the range.
By their numbers in this assay, from the lowest: compound 1; then compounds 2, 4 and 3 (each within the scatter of the next, the first and the last beyond it).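

Working notes: in this assay the step with only the methyl on the amine nitrogen in the ring, a number 9 percentage points lower from compound 3 to compound 4 (within the scatter), shows that methyl in place of hydrogen at this position cannot be told apart from the scatter, which the earlier step from the pyrrolidine to the piperidine could not show because it changed the ring and the methyl together. Fluoro in place of trifluoromethyl on an aromatic carbon also stays unresolved in this assay, with a number 9 percentage points higher from compound 2 to compound 4 (within the scatter), while 1-methylpiperidin-3-yl in place of 1-methylpyrrolidin-3-yl with the methyl kept gives a number 21 percentage points higher from compound 1 to compound 4 (beyond the scatter), so among these three single changes only the change of ring lies beyond the scatter. No measurement at hand offers an explanation for any of these steps.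

The compounds shown do not tell whether an ethyl group, a longer chain or an acetyl group on the same amine nitrogen would also stay within the scatter of hydrogen and methyl. Among these compounds, they also hold no pair that tests hydrogen against methyl on the pyrrolidine nitrogen, or a nitrile or chloro group in place of fluoro on the aromatic carbon.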